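A few compounds are considered here, and "the series" means these few. Any claim that something is new, unique, unknown or untested is made for them only; others in the source may bear on it.

Values in a functional assay on HCC827 cells (Homo sapiens) for cytotoxicity, read by MTT assay, with a stated time of 72 h; a lower number here means a stronger inhibitor, a higher number a weaker inhibitor:
- Compound 1 `Cc1cccc(Nc2nc3cnc(Nc4ccc(N5CCN(C)CC5)cc4)nc3n2C2CCCC2)c1` gives < 0.01 nM as a limit of the assay.
- Compound 2 `CN1CCN(c2ccc(Nc3ncc4nc(Nc5cccc(C(=O)Nc6ccc(Cl)cc6)c5)n(C5CCCC5)c4n3)cc2)CC1` gives 2900 nM as the only actual number.

Compound 3 `CN1CCN(c2ccc(Nc3ncc4nc(Nc5cccc(NC(=O)c6ccccc6)c5)n(C5CCCC5)c4n3)cc2)CC1` differs from compound 2 by benzamido in place of (4-chlorophenyl)carbamoyl on an aromatic carbon with benzamido in place of (4-chlorophenyl)carbamoyl on an aromatic carbon. Within the data shown here, the one measured step that bears on this is an at least 290000-fold higher number from compound 1 to compound 2 (5.46 log units; beyond the scatter) when (4-chlorophenyl)carbamoyl replaced methyl. That step swapped a small group for a ring-bearing one, whereas both groups here carry a ring, so little movement is expected. The expected change is a 1.5-fold lower number from compound 2 to compound 3 (0.16 log units; within the scatter) and thus none beyond the scatter. For compound 3 the estimate is 2000 nM with an expected range of 300 nM to 10000 nM in this measurement.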

Compound 3, half-maximal inhibitory concentration: 15 nM
Beside the measured number, compound 3's estimate is 130-fold (2.12 log units) above it; measured number outside the range, below it.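

In this assay, this position separates two groups that both carry a ring: a 190-fold lower number from compound 2 to compound 3 (2.29 log units; beyond the scatter), so a ring here does not by itself set the number. Benzamido still falls well short of methyl, with an at least 1500-fold higher number from compound 1 to compound 3 (3.17 log units; beyond the scatter). That step is open-ended, since the value of compound 1 is a limit: the limit of < 0.01 nM in this assay, at which 1 of the 3 values shown sits.

From the compounds shown here alone, whether the change from compound 2 to compound 3 comes from losing the chlorine or from the amide running the other way remains open. So does how an amine or a longer chain would read at this place.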